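Benzyl thioimidates on rat aorta: dropping the methoxy

This account rests on a few compounds, and the source may have more. Where it says the series, first, only, none or still open, it means among the compounds named here.

Measured so far:
compound 1 `S=C(NCc1ccccc1)c1cccs1`: 240000 nM
compound 2 `COc1ccc(C(=N)SCc2ccccc2)cc1`: 257000 nM
compound 3 `N=C(SCc1ccccc1)c1cccs1`: 263000 nM

In a functional assay on thoracic aorta (Rattus norvegicus, strain Wistar) (on this read-out higher numbers stand for weaker inhibition and lower numbers for stronger inhibition), compound 1 gives 240000 nM, compound 2 gives 257000 nM and compound 3 gives 263000 nM. The three numbers lie within the usual scatter of one another. Compound 2 is nearest to compound 3, and its gap to compound 1 is also within the scatter, so no ranking among the three can be read from these values. Going by the values given here, the data hold no pair of measured compounds that differs in a single place, so no measured step exists to rest a forecast on.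

Compound 4 `N=C(SCc1ccccc1)c1ccccc1` is the next member. Relative to compound 2 it carries hydrogen in place of methoxy on an aromatic carbon.

Nothing among the three measured compounds, whose values sit together within scatter, points to a direction for this change. The step from compound 2 to compound 4 in this assay is therefore expected to be none beyond the scatter, a 1.0-fold lower number from compound 2 to compound 4 (0.01 log units; within the scatter). Compound 4 is estimated at 250000 nM, with an expected range from 120000 nM to 520000 nM.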

Compound 4, half-maximal inhibitory concentration in the thoracic aorta assay: 427000 nM
For compound 4 the middle estimate is 1.7-fold (0.23 log units) below the measured one; low and high end bracket the measured number.
By their numbers in the thoracic aorta assay, from the lowest: compounds 1, 2, 3 and 4 (each within the scatter of the next).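

In the thoracic aorta assay, hydrogen in place of methoxy on the aromatic carbon gives a 1.7-fold higher number from compound 2 to compound 4 (0.22 log units; within the scatter), so this first single-place step in the series shows no change in inhibition that can be told from the scatter. In a physicochemical assay for pharmacokinetics, in phosphate buffer, with a stated time of 30 min, at pH 7.4, tested at 1 mM, in the absence of a further agent (a higher number here means that the compound lasts longer, a lower number that the compound disappears faster), compound 2 gives 0.289 h and compound 4 gives 0.0602 h. Of the two read-outs, only the half-life in phosphate buffer separates the pair, so this place, para to a large group, matters for how long the compound lasts even though it shows no readable effect on inhibition: the measured half-life of compound 2, 0.289 h, and of compound 4, 0.0602 h, a 4.8-fold lower number (0.68 log units; beyond the scatter)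

On these data alone, this rests on a single pair, so it remains open whether the longer half-life is specific to methoxy or would also come with another group at this place, such as a methyl, a chlorine or a dimethylamino group. As far as these compounds go, it also remains open whether any such group would move inhibition in the thoracic aorta assay beyond the scatter, and whether the same change would act alike on the core of compound 3.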